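Moving one chlorine on the aryl group of compound 2

The source may hold more compounds than are shown below. What is called first, only, known or untested is meant among the compounds shown, and "the series" means these compounds.

Of the compounds shown here, two of a shared core have been measured in an assay for binding affinity to dual specificity mitogen-activated protein kinase kinase 4 (Homo sapiens), read by KINOMEscan, tested at 100 nM; on this read-out lower numbers stand for a stronger effect and higher numbers for a weaker effect at the one concentration tested. Compound 1 `CCCS(=O)(=O)Nc1ccc(F)c(C(=O)c2n[nH]c3ncc(-c4ccccc4OC)cc23)c1F` gives 1.9%. Compound 2 `CCCS(=O)(=O)Nc1ccc(F)c(C(=O)c2n[nH]c3ncc(-c4cc(Cl)cc(Cl)c4)cc23)c1F` gives 73%, the higher of the two numbers and thus the weaker of the pair in this assay, with compound 1 the nearest and lower neighbour. Among the compounds with values here, the only measured step, a number 71.1 percentage points higher from compound 1 to compound 2 (beyond the scatter), shows that swapping the aryl group on the shared core can shift the read-out by a great deal.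

Compound 3 `CCCS(=O)(=O)Nc1ccc(F)c(C(=O)c2n[nH]c3ncc(-c4ccc(Cl)c(Cl)c4)cc23)c1F` is not yet measured. It differs from compound 2 in this way: 3,4-dichlorophenyl in place of 3,5-dichlorophenyl on an aromatic carbon. Within the data shown here, no measured step shows what moving one chlorine within a dichlorophenyl group does, so the step from compound 1 to compound 2 bears on it only loosely, as a sign that the aryl group matters strongly. A step of any size in this assay is therefore possible, and the expectation is a step of a number 28 percentage points lower from compound 2 to compound 3 (beyond the scatter), with wide uncertainty. Compound 3 is estimated at 45%, within a range from 8% to 85%.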

Compound 3, a percentage reported as activity, at one concentration (the size of the read-out at that concentration, not a potency): 45%
Estimate against measurement, compound 3: no gap at the digits printed, and the stated range covers the measured number.
By their numbers in this assay, from the lowest: compound 1; then compound 3; then compound 2.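

Keeping the same two chlorines and changing only where one of them sits on the aryl group gives a number 28 percentage points lower from compound 2 to compound 3 (beyond the scatter) in this assay. This shows that the read-out at this position depends on the arrangement of the atoms on the aryl group, and not only on which atoms it carries, since the 3,5-dichlorophenyl and 3,4-dichlorophenyl groups have the same atoms joined differently. Even so, the 3,4-dichlorophenyl group remains well short of the 2-methoxyphenyl group, with a number 43.1 percentage points higher from compound 1 to compound 3 (beyond the scatter) in this assay, and nothing at hand explains why the placement of a chlorine matters here.

The compounds shown leave open whether the low number of compound 1 comes from the methoxy group itself or from where it sits on the ring, a question that a 4-methoxyphenyl group or a plain phenyl group would help to answer. Also open, on these data alone, is how a 2,3-dichlorophenyl group or a ring carrying a single chlorine, such as 4-chlorophenyl, would compare with the two dichlorophenyl groups.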